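The source may report more compounds than this note shows. Statements on the series, on what has been measured and on what is new or still open speak of the compounds shown alone.

Compound 2 `O=C(CSc1ncccn1)N/N=c1/scc(-c2ccccc2)n1-c1ccccc1` gives 107 ug/mL in an ADME assay on NIH3T3 cells (Mus musculus) for cytotoxicity, read by MTT assay, with a stated time of 24 h (on this read-out lower numbers stand for stronger inhibition and higher numbers for weaker inhibition), the higher of the two numbers measured in this series. Compound 1 `COc1ccc(-c2cs/c(=N/NC(=O)CSc3nnnn3-c3ccccc3)n2-c2ccccc2)cc1`, which carries a different sulfur-linked ring and an added methoxy, gives 11.7 ug/mL in this assay, a gap beyond the usual scatter. Compound 3 `COc1ccc(-c2cs/c(=N/NC(=O)CSc3ncccn3)n2-c2ccccc2)cc1` changes compound 2 in one place: methoxy in place of hydrogen on an aromatic carbon. Among the measured compounds shown here, no measured pair shows this change alone, so the expectation leans on the lower number of compound 1 with its 11.7 ug/mL. A modest drop in the number is expected, a 2.7-fold lower number from compound 2 to compound 3 (0.43 log units; beyond the scatter), perhaps just beyond the scatter. Compound 3 is therefore estimated at 40 ug/mL, within 12 ug/mL to 130 ug/mL.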

Compound 3, half-maximal inhibitory concentration: 450 ug/mL
The estimate for compound 3 lay 11-fold (1.05 log units) below the measured number, outside the stated range (above it).
By their numbers in this assay, from the lowest: compound 1; then compound 2; then compound 3.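

Read alone, phenyl to 4-methoxyphenyl does not lower the number in this assay: it gives a 4.2-fold higher number from compound 2 to compound 3 (0.62 log units; beyond the scatter), the opposite direction from what the earlier pair suggested. With the methoxy kept, pyrimidin-2-yl in place of 1-phenyl-1H-tetrazol-5-yl on the sulfur gives a 38-fold higher number from compound 1 to compound 3 (1.59 log units; beyond the scatter), so the group on the sulfur can move this number by a large step. No measurement shown here explains either step. Still open, from the compounds shown here alone, is how a hydroxy or an amine at this position would read, and whether the methoxy step holds with 1-phenyl-1H-tetrazol-5-yl on the sulfur.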